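A Chloro Substituent on a Weak Lactone Cytotoxin

A few compounds are considered here, and "the series" means these few. Any claim that something is new, unique, unknown or untested is made for them only; others in the source may bear on it.

compound 1 `O=C1OC[C@H](Cc2ccccc2)[C@H]1Cc1ccccc1`: 77000 nM
compound 2 `CCCCCCCOc1ccc(C[C@H]2C(=O)OC[C@@H]2Cc2ccccc2)cc1`: > 100000 nM (a limit)

For the measured compounds named here, in a functional assay on HL-60 cells (Homo sapiens) for cytotoxicity, read by WST assay, with a stated time of 48 h (a lower number here means that less compound is needed, a higher number that more compound is needed for the effect), compound 1 gives 77000 nM, the only plain number among the two values shown. Compound 2 reaches only the limit of this assay, > 100000 nM. Going by the values given here, the one step measured so far is an at least 1.2-fold higher number from compound 1 to compound 2 (0.11 log units; that floor lies within the scatter), where heptyloxy replaced hydrogen on an aromatic carbon; its size rests on the limit of > 100000 nM in this assay, at which 1 of the 2 values shown sits, and so cannot be read as a real change.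

Compound 3 `O=C1OC[C@H](Cc2ccccc2)[C@H]1Cc1ccc(Cl)cc1` differs from compound 1 by chloro in place of hydrogen on an aromatic carbon. Among the compounds with values here, only the step from compound 1 to compound 2 bears on it, and that step did not clearly exceed the scatter, so a small chlorine entering at an aromatic carbon is expected to leave the number about where compound 1 stands. Compound 3 is therefore expected to give 70000 nM in this assay, between 30000 nM and 160000 nM, an estimated step of a 1.1-fold lower number from compound 1 to compound 3 (0.04 log units; within the scatter).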

Compound 3, half-maximal effective concentration: 36000 nM
Compound 3: middle estimate off by 1.9-fold (0.29 log units), on the high side; the measured number falls inside the stated range.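

In this assay, this aromatic position, para to a large group, proves sensitive to a single added atom: chloro in place of hydrogen gives a 2.1-fold lower number from compound 1 to compound 3 (0.33 log units; beyond the scatter), a modest but readable change that the earlier step could not show. Swapping the long chain for chloro at the same position gives an at least 2.7-fold lower number from compound 2 to compound 3 (0.44 log units; beyond the scatter), so a small group and heptyloxy are clearly apart here. That size is only a floor, since compound 2 stands at a limit and not at a plain number: the limit of > 100000 nM in this assay, at which 1 of the 3 values shown sits.

With only hydrogen, chloro and heptyloxy shown at this position, it remains open whether other small groups, such as fluoro or methoxy, would lower the number as chloro does. On these data alone, how an amine or a carboxylic acid at the same position would behave also remains open.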